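Trading a but-1-en-1-yl group for cyclopropyl

A few compounds are considered here, and "the series" means these few. Any claim that something is new, unique, unknown or untested is made for them only; others in the source may bear on it.

Compound 1, `C/C=C/C(=O)N(Cc1ccc(OC)c(N)c1)c1cc(OC)c(OC)c(OC)c1`, gives 310 nM in a functional assay on KYSE-450 cells (Homo sapiens) for inhibition, read by MTT assay, with a stated time of 48 h; a lower number here means a stronger inhibitor, a higher number a weaker inhibitor.
Compound 2, `CC/C=C/C(=O)N(Cc1ccc(OC)c(O)c1)c1cc(OC)c(OC)c(OC)c1`, gives 72 nM in this assay.
Compound 3, `COc1ccc(CNc2cc(OC)c(OC)c(OC)c2)cc1C`, gives 73800 nM in this assay.

Among these three, compound 2 has the lowest number, so it is the strongest inhibitor shown. Compound 1 stands nearest to it and compound 3 furthest, and both gaps lie beyond the usual scatter of repeated measurements. Going by the values given here, compound 3, which has no carbonyl group at all on the shared core, sits far above the other two, suggesting that the carbonyl-bearing group matters a great deal here, though with only three compounds this is no more than a hint.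

The unmeasured compound 4, `COc1ccc(CN(C(=O)C2CC2)c2cc(OC)c(OC)c(OC)c2)cc1O`, keeps everything in compound 2 except one group on the carbonyl carbon: cyclopropyl in place of but-1-en-1-yl on a carbonyl carbon. Among the compounds with values here, no pair of measured compounds shows exactly this kind of swap, so the direction of the step has to be judged without a direct precedent. Because compound 3 gives 73800 nM without any carbonyl group while compound 2, which keeps one, gives 72 nM, a return toward the weak result of compound 3 is not expected as long as a carbonyl-bearing group is retained. A modest loss relative to compound 2 seems the more likely outcome, so the expected step is a 4.2-fold higher number from compound 2 to compound 4 (0.62 log units; beyond the scatter). Compound 4 is therefore estimated at 300 nM, with a range from 70 nM to 1500 nM in this assay.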

Compound 4, half-maximal inhibitory concentration: 80 nM
Compound 4: middle estimate off by 3.8-fold (0.57 log units), on the high side; the measured number falls inside the stated range.
By their numbers in this assay, from the lowest: compounds 2 and 4 (each within the scatter of the next); then compound 1; then compound 3.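

In this assay, replacing but-1-en-1-yl with cyclopropyl on a carbonyl carbon gives a 1.1-fold higher number from compound 2 to compound 4 (0.05 log units; within the scatter), so this pair shows no measurable difference. Going by these compounds alone, this is the first direct comparison at this position, and it shows that, in this pair, the double bond outside aromatic rings is not required for a low number: an open chain of 4 heavy atoms and a three-membered ring of 3 heavy atoms give results that cannot be told apart. No supporting measurements are available to explain why these two different groups match.

The compounds shown leave open how far this tolerance extends, for example whether a plain methyl group, a cyclopentyl ring or a phenyl ring on the carbonyl carbon would also keep the number close to those of compound 2 and compound 4. They also leave open whether the same swap would give a similar result on a core carrying the amino group of compound 1 in place of the hydroxyl group.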